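Compound 2 and the Expected Step to Compound 3

The compounds below may be only part of what the source reports. "The series", "measured", "known", "first", "only" and "open" are said of these compounds alone.

The two measured compounds share one core and differ only in the group on the ring nitrogen. Compound 1 `O=C(/C=C/c1ccccc1)c1ccc(N2CCN(c3cccc(Cl)c3)CC2)cc1` carries a chloro on an aromatic carbon, and in a functional assay on the whole organism (strain Kunming) for inhibition, with Mus musculus as the target, with a stated time of 1 h, at a dose of 40 mg/kg by the oral route (on this read-out higher numbers stand for more inhibition at the one dose given (going by the name of the read-out) and lower numbers for less inhibition), compound 1 gives 14.1%. Compound 2 `O=C(/C=C/c1ccccc1)c1ccc(N2CCN(c3cccc(C(F)(F)F)c3)CC2)cc1` carries a trifluoromethyl there instead, and in this assay compound 2 gives 25%; it stands highest of the two numbers, as the step of a number 10.9 percentage points higher from compound 1 to compound 2 (beyond the scatter) shows. Compound 3 `COc1ccc(S(=O)(=O)N2CCN(c3ccc(C(=O)/C=C/c4ccccc4)cc3)CC2)cc1` brings a different kind of change: (4-methoxyphenyl)sulfonyl in place of 3-(trifluoromethyl)phenyl on an amine nitrogen in a ring. Among the measured compounds shown here, no measured step exchanges a whole aromatic ring for a sulfonyl group, so the single step in hand, a number 10.9 percentage points higher from compound 1 to compound 2 (beyond the scatter), bears only loosely on this change. A step within the scatter, in either direction, is therefore expected: a number 3 percentage points lower from compound 2 to compound 3 (within the scatter). Compound 3 is expected to reach 22%, between 5% and 45%.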

Compound 3, a percentage reported as inhibition, in the whole organism at one dose (the size of the read-out at that dose, not a potency): 45.2%
Estimate against measurement, compound 3: 23.2 percentage points below, and the stated range ends below it.
By their numbers in this assay, from the lowest: compound 1; then compound 2; then compound 3.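

In this assay, the ring amine nitrogen proves open to a change far larger than the swap of one ring substituent: (4-methoxyphenyl)sulfonyl in place of 3-(trifluoromethyl)phenyl gives a number 20.2 percentage points higher from compound 2 to compound 3 (beyond the scatter), and in place of 3-chlorophenyl it gives a number 31.1 percentage points higher from compound 1 to compound 3 (beyond the scatter). So a direct bond from this nitrogen to an aromatic ring is not needed for the read-out, and a sulfonyl group, which brings hydrogen-bond acceptors that the leaving groups lack, is accepted at this place. No measurement at hand explains the rise.

On these data alone, compound 3 alters the sulfonyl link and the ring substituent together, so the share of each in the rise stays open. As far as these compounds go, how a phenylsulfonyl without the methoxy, or a small methylsulfonyl, would behave on this nitrogen also remains open.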